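Moving a trifluoromethyl group on a three-armed pyridine scaffold

The source may report more compounds than this note shows. Statements on the series, on what has been measured and on what is new or still open speak of the compounds shown alone.

Three compounds were tested in a functional assay on HCT-15 cells (Homo sapiens) for inhibition; on this read-out lower numbers stand for stronger inhibition and higher numbers for weaker inhibition. Compound 1 `Oc1cccc(-c2cc(-c3ccccc3C(F)(F)F)cc(-c3ccccc3O)n2)c1` gives 9010 nM, compound 2 `Oc1cccc(-c2cc(-c3cccc(C(F)(F)F)c3)cc(-c3ccccc3O)n2)c1` gives 6460 nM, and compound 3 `Oc1ccc(-c2cc(-c3ccccc3C(F)(F)F)cc(-c3ccccc3O)n2)cc1` gives 8990 nM. The change 3-(trifluoromethyl)phenyl in place of 2-(trifluoromethyl)phenyl on an aromatic carbon produced a 1.4-fold lower number from compound 1 to compound 2 (0.14 log units; within the scatter). The two cores differ by 4-hydroxyphenyl in place of 3-hydroxyphenyl on an aromatic carbon, which produced a 1.0-fold lower number from compound 1 to compound 3 (0.00 log units; within the scatter).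

Compound 4 `Oc1ccc(-c2cc(-c3cccc(C(F)(F)F)c3)cc(-c3ccccc3O)n2)cc1` has not been measured in this assay . It arises from compound 3 by 3-(trifluoromethyl)phenyl in place of 2-(trifluoromethyl)phenyl on an aromatic carbon, the same kind of change as from compound 1 to compound 2, though here the place is meta to a 4-hydroxyphenyl group rather than meta to a 3-hydroxyphenyl group. For compound 4 the expected step is a 1.4-fold lower number from compound 3 to compound 4 (0.14 log units; within the scatter), resting on the measured 1.4-fold lower number from compound 1 to compound 2 (0.14 log units; within the scatter). Compound 4 is therefore estimated at 6500 nM, with a range from 3000 nM to 14000 nM.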

Compound 4, half-maximal inhibitory concentration: > 50000 nM
Compound 4: only a limit was reported; the forecaster's own chance of this, stated with the estimate: 0%; middle value at least 7.6-fold (0.88 log units) away from the limit.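

On the core carrying the 4-hydroxyphenyl group, the change to 3-(trifluoromethyl)phenyl gives an at least 5.5-fold higher number from compound 3 to compound 4 (0.74 log units; beyond the scatter), so it does not carry over unchanged from the core of compound 1: the same change on two cores in this assay, a 1.4-fold lower number (0.14 log units; within the scatter) from compound 1 to compound 2 and an at least 5.5-fold higher number (0.74 log units; beyond the scatter) from compound 3 to compound 4, at least 7.7-fold (0.88 log units) apart, beyond the scatter of two such steps

The change to 4-hydroxyphenyl also depends on its core, giving an at least 7.7-fold higher number from compound 2 to compound 4 (0.88 log units; beyond the scatter): the same change on two cores in this assay, a 1.0-fold lower number (0.00 log units; within the scatter) from compound 1 to compound 3 and an at least 7.7-fold higher number (0.88 log units; beyond the scatter) from compound 2 to compound 4, at least 7.7-fold (0.88 log units) apart, beyond the scatter of two such steps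

In this assay compound 4 gives > 50000 nM, which is a limit and not a number, so the true sizes of both steps stay unknown, and these four compounds do not show why the two changes act differently together.

From the compounds shown here alone, it remains open whether the sharp change in the read-out would also appear if a nitrile or an amine replaced the trifluoromethyl group. Going by these compounds, it is also open whether other hydroxyl placements would behave the same way.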